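Isoquinolinyloxy in place of pyrimidinylsulfanyl on the ketone side chain

The source may hold more compounds than are shown below. What is called first, only, known or untested is meant among the compounds shown, and "the series" means these compounds.

Measured so far:
compound 1, `CC(C)c1cc(OCC(=O)[C@H](CC(=O)O)NC(=O)[C@@H](NC(=O)COc2cccc3ccccc23)C(C)C)no1` — in a functional assay on Jurkat cells (Homo sapiens) for inhibition (a higher number here means a weaker inhibitor, a lower number a stronger inhibitor), compound 1 gives only a limit, > 200000 nM.
compound 2, `CC(C)[C@H](NC(=O)COc1cccc2ccccc12)C(=O)N[C@@H](CC(=O)O)C(=O)CSc1nccc(C(F)(F)F)n1` — in this assay compound 2 gives only a limit, > 200000 nM.

Compound 2 therefore stands at a limit of this assay, not at a number; both values shown sit at the limit of > 200000 nM in this assay, at which 2 of the 2 values shown sit. For the measured compounds named here, the one measured step, a step that the two limits leave unreadable from compound 1 to compound 2, is accordingly unreadable in size and direction, and nothing measured tells how far either compound lies past that limit.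

Compound 3, `CC(C)[C@H](NC(=O)COc1cccc2ccccc12)C(=O)N[C@@H](CC(=O)O)C(=O)COc1cncc2ccccc12`, differs from compound 2 by (isoquinolin-4-yl)oxy in place of (4-(trifluoromethyl)pyrimidin-2-yl)sulfanyl on a saturated chain carbon bound to a carbonyl carbon. Going by the values given here, the only step that bears on this change is the unreadable one from compound 1 to compound 2, so no size can be carried over; the working expectation is that compound 3 also reaches only the limit of this assay, with the expected step that the limit leaves unreadable from compound 2 to compound 3. Compound 3 is estimated at 300000 nM, expected range 100000 nM to 1000000 nM.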

Compound 3, half-maximal inhibitory concentration: 166000 nM
For compound 3 the middle estimate is 1.8-fold (0.26 log units) above the measured one, within the range that was stated.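

In this assay, for the compounds shown here, compound 3 gives 166000 nM, the only value on this side chain that is a number rather than a limit. Against the limits, the readable steps are an at least 1.2-fold lower number from compound 2 to compound 3 (0.08 log units; that floor lies within the scatter) and an at least 1.2-fold lower number from compound 1 to compound 3 (0.08 log units; that floor lies within the scatter); both are floors only, so neither establishes a change beyond the scatter, and the step between the other two compounds stays unreadable. Compound 1 and compound 2 each remain at a limit: the limit of > 200000 nM in this assay, at which 2 of the 3 values shown sit.

The change to compound 3 replaces the ring and the linking sulfur together, so a (isoquinolin-4-yl)sulfanyl group would be needed to separate the two. Also open, on these data alone, is whether an amine or a carboxylic acid on the isoquinolin-4-yl ring would move the value well beyond the scatter.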